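The source may report more compounds than this note shows. Statements on the series, on what has been measured and on what is new or still open speak of the compounds shown alone.

Within the data shown here, compound 1, with the structure `COc1ccc(OC)c(C2=C(c3cc(OC)c(OC)c(OC)c3)C(=O)CC2O[SiH2]C(C)(C)C)c1`, is the only member of this small set to give a numerical result in an ADME assay on L132 cells (Homo sapiens) for cytotoxicity, read by MTT assay, with a stated time of 72 h; a lower number here means a stronger inhibitor, a higher number a weaker inhibitor: compound 1 gives 100 ug/mL. Compound 2, with the structure `COc1ccc(C2=C(c3cc(OC)c(OC)c(OC)c3)C(=O)C(O)C2)cc1F`, is reported only as a limit of the assay rather than a number, in this assay compound 2 giving < 1 ug/mL. Among the measured compounds shown here, the set therefore offers one real number and (the limit of < 1 ug/mL in this assay, at which 1 of the 2 values shown sits), and no step between two measured compounds can be drawn from it.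

Compound 3, with the structure `COc1cc(C2=C(c3ccccc3)C(O[SiH2]C(C)(C)C)CC2=O)cc(OC)c1OC`, differs from compound 1 in one place: phenyl in place of 2,5-dimethoxyphenyl on a double-bonded ring carbon. For the measured compounds named here, since no measured pair shows how this assay answers a change of this kind, the direction of the step is uncertain; the carbon-bearing silyl ether of compound 1 is kept, and the simpler phenyl could leave the read-out near where compound 1 sits or move it somewhat toward stronger cytotoxicity. The step from compound 1 to compound 3 in this assay is expected to be a 2.0-fold lower number from compound 1 to compound 3 (0.30 log units; within the scatter). For compound 3 the expected value is 50 ug/mL, with a likely range from 10 ug/mL to 100 ug/mL.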

Compound 3, half-maximal inhibitory concentration: > 100 ug/mL
Compound 3: no number, only a limit; the forecaster's own chance of this, stated with the estimate: 25%; at least 2.0-fold (0.30 log units) between middle value and limit.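

Compound 3 is reported in this assay only as a limit, > 100 ug/mL. Among these compounds, exchanging 2,5-dimethoxyphenyl for phenyl on the double-bonded ring carbon gives the first step in this set that shows how the assay answers a change at this position, a number no lower from compound 1 to compound 3 (the limit leaves the size open), so with the silyl ether kept, the plain phenyl ring does not move the read-out toward stronger cytotoxicity. The direction of this step can be stated, but its size cannot be read because the value of compound 3 is a limit rather than a number: the limit of > 100 ug/mL in this assay, at which 1 of the 3 values shown sits.

The compounds shown leave open whether a ring carrying a single methoxy group, an amino group or a carboxylic acid at this same position would bring the read-out into a measurable range in this assay. They also leave open what the silyl ether itself contributes, since compound 2 differs from compound 1 and compound 3 in more than one place and so cannot be set against either of them as a step.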